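Dipropylamino exchange on the shared core

This account rests on a few compounds, and the source may have more. Where it says the series, first, only, none or still open, it means among the compounds named here.

Compound 1 `O=C1C(NC2CC2)=CC(=O)c2c1nc1n2[C@H]2OC[C@@H](O)[C@H]2OC1` carries a cyclopropylamino group. In a functional assay on HeLa cells (Homo sapiens) for inhibition, read by sulforhodamine B assay (a higher number here means a weaker inhibitor, a lower number a stronger inhibitor), compound 1 gives only a limit, > 16000 nM, and so sits at the limit of > 16000 nM in this assay, at which 1 of the 3 values shown sits. Compound 2 `O=C1C=C(Nc2cccc(Cl)c2)C(=O)c2c1nc1n2[C@H]2OC[C@@H](O)[C@H]2OC1` gives 6040 nM in this assay; compound 3 `CCCc1ccc(NC2=CC(=O)c3nc4n(c3C2=O)[C@H]2OC[C@@H](O)[C@H]2OC4)cc1` gives 4990 nM. For the measured compounds named here, the one measured step, a 1.2-fold lower number from compound 2 to compound 3 (0.08 log units; within the scatter), exchanges one arylamino group for another and does not bear on an alkylamino change. Compound 4 `CCCN(CCC)C1=CC(=O)c2c(nc3n2[C@H]2OC[C@@H](O)[C@H]2OC3)C1=O` differs from compound 1 by dipropylamino in place of cyclopropylamino on a double-bonded ring carbon. Going by the values given here, with compound 1 known only as a limit and no comparable step measured, no direction can be read from the numbers, and compound 4 is expected to remain weak, near the limit. The estimate for compound 4 is 16000 nM, between 5000 nM and 50000 nM, a step of a number no higher from compound 1 to compound 4 (the limit leaves the size open) that is expected rather than measured.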

Compound 4, half-maximal inhibitory concentration: > 16000 nM
Compound 4 gave a limit, no number; the forecaster's own chance of this, stated with the estimate: 55%; the middle value sits exactly at the limit.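

No step can be read between compound 1 and compound 4, as both give only a limit: the limit of > 16000 nM in this assay, at which 2 of the 4 values shown sit.

The compounds shown leave open whether any alkylamino group on the shared core gives a readable number in this assay at all.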